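A few compounds are considered here, and "the series" means these few. Any claim that something is new, unique, unknown or untested is made for them only; others in the source may bear on it.

In a functional assay on BaF3 cells (Mus musculus) for inhibition, read by CCK-8 assay, with a stated time of 72 h (a higher number here means a weaker inhibitor of growth, a lower number a stronger inhibitor of growth), three compounds have been measured so far. Compound 2 `Cc1ccc(NC(=O)Nc2ccc(Oc3cc(N)ncn3)cc2)cc1C(F)(F)F` gives > 10000 nM, which is a limit of the assay and not a number. Compound 3 `Cc1ccc(NC(=O)Nc2ccc(Oc3cc(N4CCNC[C@H]4C)ncn3)cc2)cc1C(F)(F)F` gives 9670 nM, and compound 1 `CC(=O)Nc1cc(Oc2ccc(NC(=O)Nc3ccc(CN4CCN(C)CC4)c(C(F)(F)F)c3)cc2)ncn1` gives 50 nM, so compound 3 has the higher of the two actual numbers.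

The unmeasured compound 4 `CNCCN(C)c1cc(Oc2ccc(NC(=O)Nc3ccc(C)c(C(F)(F)F)c3)cc2)ncn1` differs from compound 3 in one place: methyl(2-(methylamino)ethyl)amino in place of 2-methylpiperazin-1-yl on an aromatic carbon. Methyl(2-(methylamino)ethyl)amino stands in place of 2-methylpiperazin-1-yl on an aromatic carbon, and the entering group has no ring.

Within the data shown here, only one measured step bears on this place: an at least 1.0-fold lower number from compound 2 to compound 3 (0.01 log units; that floor lies within the scatter). It starts from a limit, so it gives a floor rather than a true size, and that floor lies within the scatter. Among the measured compounds shown here, no measured step compares a group without a ring against 2-methylpiperazin-1-yl. No shift beyond the scatter is therefore expected in this assay, in either direction, and compound 4 is expected to stay close to compound 3 at 9670 nM. The expected change is a 1.2-fold lower number from compound 3 to compound 4 (0.08 log units; within the scatter). For compound 4 the estimate is 8000 nM, with an expected range from 3000 nM to 20000 nM.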

Compound 4, concentration for 50% growth inhibition: > 10000 nM
Compound 4 ended at the assay's limit (the forecaster's own chance of this, stated with the estimate: 35%); middle value at least 1.2-fold (0.09 log units) away from the limit.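

Setting methyl(2-(methylamino)ethyl)amino, which has no ring, in place of 2-methylpiperazin-1-yl on this aromatic carbon gives an at least 1.0-fold higher number from compound 3 to compound 4 (0.01 log units; that floor lies within the scatter) in this assay, so this change shows no readable gain or loss, and neither the ring nor the defined stereocentre of the leaving group is shown to matter here. The step from compound 2 to compound 4 joins two limits and cannot be read. Amino, 2-methylpiperazin-1-yl and the open chain have now all been tried at this place without any readable step beyond the scatter, and the results crowd against the top of the read-out: the limit of > 10000 nM in this assay, at which 2 of the 4 values shown sit.

Any real difference between compound 3 and compound 4 remains hidden, as the limit of compound 4 gives no true number to compare. Also open, going by these compounds, is whether another group at this place, such as morpholin-4-yl, a carboxylic acid or a longer chain ending in an amine, would give a value clearly below that limit on the core shared by compound 2, compound 3 and compound 4.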